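A few compounds are considered here, and "the series" means these few. Any claim that something is new, unique, unknown or untested is made for them only; others in the source may bear on it.

In an ADME assay on HEK293 cells (Homo sapiens) for cytotoxicity, read by luminescence, with a stated time of 72 h (a lower number here means that less compound is needed, a higher number that more compound is needed for the effect), compound 1 (`CCOC(=O)c1c(-c2ccccc2)[nH]c2cc(OC)ccc2c1=O`) gives > 22000 nM as a limit of the assay. Compound 2 (`CCOC(=O)c1c(-c2cccc([N+](=O)[O-])c2)[nH]c2cc(OC)ccc2c1=O`) gives > 22000 nM as a limit too, so it stands with no number of its own. Going by the values given here, the only measured step is a step that the two limits leave unreadable from compound 1 to compound 2 and has no readable size. The picture so far is the limit of > 22000 nM in this assay, at which 2 of the 2 values shown sit, and nothing more.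

Compound 3 (`CCOC(=O)c1c(-c2cccc(CO)c2)[nH]c2cc(OC)ccc2c1=O`) carries hydroxymethyl in place of the nitro of compound 2, on an aromatic carbon, meta to a large group (hydroxymethyl in place of nitro on an aromatic carbon). Among the compounds with values here, with no measured step to scale from, no step beyond the scatter is expected in this assay and the direction stays open. The expected change is a step that the limit leaves unreadable from compound 2 to compound 3 in this estimate. Compound 3 is expected near 25000 nM with an estimated range of 12000 nM to 50000 nM and will most likely be reported as a limit again.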

Compound 3, half-maximal effective concentration: > 22000 nM
Compound 3: only a limit was reported; the forecaster's own chance of this, stated with the estimate: 85%; the middle value does not contradict the limit.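

Compound 3 gives > 22000 nM, again a limit of the assay. Going by these compounds alone, no step to compound 3 from compound 1 or compound 2 can be read. The compounds shown leave open whether any change at this place would give a readable value in this assay.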